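Swapping trifluoromethyl for fluoro on the benzyl group

A few compounds are considered here, and "the series" means these few. Any claim that something is new, unique, unknown or untested is made for them only; others in the source may bear on it.

In an ADME assay on L02 cells (Homo sapiens) for inhibition, read by CCK-8 assay, with a stated time of 48 h (a higher number here means a weaker inhibitor of growth, a lower number a stronger inhibitor of growth), compound 1 `Cc1ccccc1Nc1nc(Nc2ccc(N3CCN(C)CC3)cn2)ncc1Cl` gives 5980 nM and compound 2 `CCN1CCN(c2ccc(Nc3ncc(Cl)c(Nc4ccccc4C)n3)cc2)CC1` gives 970 nM. Compound 3 `CN1CCN(c2ccc(Nc3ncc(Cl)c(NCc4ccc(C(F)(F)F)cc4)n3)nc2)CC1` gives 26200 nM, the highest number of the three. Compound 4 `CN1CCN(c2ccc(Nc3ncc(Cl)c(NCc4ccc(F)cc4)n3)nc2)CC1` carries fluoro in place of trifluoromethyl on an aromatic carbon, para to a large group: fluoro in place of trifluoromethyl on an aromatic carbon. For the measured compounds named here, the only measured step bearing on this is a 4.4-fold higher number from compound 1 to compound 3 (0.64 log units; beyond the scatter), with 4-(trifluoromethyl)benzyl in place of 2-methylphenyl. Going by the values given here, no measured step isolates the trifluoromethyl itself, so a smaller, downward change in this assay is expected. The estimated step is a 1.7-fold lower number from compound 3 to compound 4 (0.24 log units; within the scatter). Compound 4 is expected at 15000 nM, with an estimated range of 6000 nM to 40000 nM.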

Compound 4, concentration for 50% growth inhibition: 39700 nM
Estimate against measurement, compound 4: 2.6-fold (0.42 log units) below, and the stated range covers the measured number.
By their numbers in this assay, from the lowest: compound 2; then compound 1; then compounds 3 and 4 (each within the scatter of the next).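

In this assay, trifluoromethyl and fluoro on this aromatic carbon, para to a large group, are not told apart, with a 1.5-fold higher number from compound 3 to compound 4 (0.18 log units; within the scatter). Both benzyl compounds now stand apart from the 2-methylphenyl compound, as a 6.6-fold higher number from compound 1 to compound 4 (0.82 log units; beyond the scatter) sits alongside a 4.4-fold higher number from compound 1 to compound 3 (0.64 log units; beyond the scatter). Nothing at hand accounts for this result.

On these data alone, whether an amine or a carboxylic acid on the same aromatic carbon would move the number beyond the scatter remains open. So does the effect of a longer chain in place of the benzyl group.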